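The source may report more compounds than this note shows. Statements on the series, on what has been measured and on what is new or still open speak of the compounds shown alone.

Measured so far:
compound 1, `CS(=O)(=O)Nc1ccc(Cl)c2c1CCCC2c1c[nH]cn1`, 2880 nM
compound 2, `CCS(=O)(=O)Nc1cccc2c1CCCC2c1c[nH]cn1`, 1070 nM
compound 3, `CCS(=O)(=O)Nc1cccc(C2CCNC2)c1`, 1000 nM

All three were read in an assay on isolated protein for binding affinity to Alpha-1D adrenergic receptor (Rattus norvegicus), read by radioligand binding; a higher number here means a weaker inhibitor, a lower number a stronger inhibitor. Compound 3 has the lowest of the three numbers, but its nearest neighbour, compound 2, sits within the scatter of it, so no order between compounds 2 and 3 can be claimed. Compound 1 lies furthest from compound 3, beyond the scatter, with the higher number of the two.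

Compound 4, `CCS(=O)(=O)Nc1cccc(-c2c[nH]cn2)c1`, has not yet been measured in this assay. The change from compound 3 is 1H-imidazol-4-yl in place of pyrrolidin-3-yl on an aromatic carbon. Among the measured compounds shown here, no pair of measured compounds differs in just this way, so there is no measured step to lean on. Compound 2 with 1070 nM and compound 1 with 2880 nM both carry the entering group on their own cores and land in the same general region as compound 3, which suggests the exchange need not move the number far. The expectation for compound 4 is a modest step toward a higher number, a 2.0-fold higher number from compound 3 to compound 4 (0.30 log units; within the scatter), though a result within the scatter would not surprise. The estimate for compound 4 is 2000 nM, with a range from 600 nM to 7000 nM.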

Compound 4, inhibition constant: < 10000 nM
Compound 4: only a limit was reported; the forecaster's own chance of this, stated with the estimate: 15%; the middle value is on the limit's open side.
By their numbers in this assay, from the lowest: compounds 3 and 2 (each within the scatter of the next); then compound 1.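

Among the compounds shown here, compound 4 gives < 10000 nM, which is a limit and not a number, so no step from compound 3 to compound 4 can be read. The compounds shown leave open whether 1H-imidazol-4-yl in place of pyrrolidin-3-yl moves the number at all, and in which direction.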